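Replacing oxolan-3-yl in compound 3 with a larger ring

The source may report more compounds than this note shows. Statements on the series, on what has been measured and on what is new or still open speak of the compounds shown alone.

Three compounds in this series have a measured value in a physicochemical assay for solubility, using the shake flask method, measured as kinetic solubility, with a stated time of 20 h, at pH 2; on this read-out lower numbers stand for lower solubility and higher numbers for higher solubility. Compound 1 (`FC(F)(F)c1cccc(-c2nc3cnc(Nc4cnccn4)cc3[nH]2)c1`) gives 155000 nM, and compound 2 (`CN1CCN(c2ccc(Nc3cc4[nH]c(-c5cccc(C(F)(F)F)c5)nc4cn3)nc2)CC1`) gives 190000 nM. Compound 3 (`FC(F)(F)c1ccc(Nc2cc3[nH]c(C4CCOC4)nc3cn2)nc1`) gives 200000 nM, which leaves it level with the other two, since all three values lie within the usual scatter of one another.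

Compound 4 (`FC(F)(F)c1ccc(Nc2cc3[nH]c([C@H]4CC[C@H](C(F)(F)F)CC4)nc3cn2)nc1`) has not yet been measured. It carries 4-(trifluoromethyl)cyclohexyl in place of the oxolan-3-yl of compound 3, on an aromatic carbon of a five-membered aromatic ring, between two ring nitrogen atoms. The change counts as follows: 4-(trifluoromethyl)cyclohexyl in place of oxolan-3-yl on an aromatic carbon. For the measured compounds named here, no two measured compounds differ in one place only, so the data hold no direct precedent for this replacement, and the size of any step has to be judged from the structural change alone. On that judgement, a fall in this assay beyond the scatter is expected, though with wide uncertainty. The estimated step runs a 5.0-fold lower number from compound 3 to compound 4 (0.70 log units; beyond the scatter). For compound 4 the expected value is 40000 nM, with an estimated range from 6000 nM to 150000 nM.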

Compound 4, solubility: 200000 nM
Beside the measured number, compound 4's estimate is 5.0-fold (0.70 log units) below it; measured number above the stated range.
By their numbers in this assay, from the lowest: compounds 1, 2, 3 and 4 (each within the scatter of the next).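

In this assay, for the compounds shown here, putting 4-(trifluoromethyl)cyclohexyl in place of oxolan-3-yl on an aromatic carbon, between two ring nitrogen atoms, gives no change at the digits printed from compound 3 to compound 4 (within the scatter), and this is the first pair that differs in one place only. In this pair, compound 3 and compound 4 stand level although the substituent goes from 5 to 10 heavy atoms, its ring oxygen and single hydrogen-bond acceptor leave, and the new group brings three fluorine atoms and 2 defined stereocentres. The data include no measurement that bears on why the two compounds stand level.

This single pair cannot show whether the same would hold for the other stereoisomer of the 4-(trifluoromethyl)cyclohexyl group, or for a piperidin-4-yl group or a carboxylic acid on the cyclohexyl ring at this position. Compound 1 and compound 2 differ from compound 3 in more than one place, so they give no reading of what an aryl group at this carbon would do on its own.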